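The source may hold more compounds than are shown below. What is called first, only, known or untested is meant among the compounds shown, and "the series" means these compounds.

Of the compounds shown here, three have been tested in an assay on isolated protein for binding affinity to histamine H2 receptor (Homo sapiens); a higher number here means a weaker inhibitor, a lower number a stronger inhibitor. Compound 1 `CCCCCC(=O)c1ccc(OCCCN2CCN(C(=O)N3CCOCC3)CC2)cc1` gives 17800 nM, and compound 2 `CCCCCC(=O)c1ccc(OCCCN2CCN(C(=O)C3CCC3)CC2)cc1` gives 10200 nM. Among the measured compounds shown here, the only single change among the measured compounds, cyclobutyl in place of morpholin-4-yl on a carbonyl carbon, yields a 1.7-fold lower number from compound 1 to compound 2 (0.24 log units; within the scatter). Compound 3 `CCOC(=O)N1CCN(CCCOc2ccc(C(=O)C3CC3)cc2)CC1` gives 79400 nM, the highest number of the three and therefore the weakest binder shown here, well beyond the scatter from both compound 1 and compound 2.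

Compound 4 `CCOC(=O)N1CCN(CCCOc2ccc(C(=O)c3ccc(OC)cc3)cc2)CC1` is not yet measured. It differs from compound 3 in one place: 4-methoxyphenyl in place of cyclopropyl on a carbonyl carbon. For the measured compounds named here, no measured step changes this part of the molecule, and the one known step, from compound 1 to compound 2, alters the other carbonyl and stays within the scatter, so it offers little guidance for this assay. Going by the values given here, the only hint is that compound 1 and compound 2, which carry a larger group on the aryl ketone than compound 3, give lower numbers, but they also differ elsewhere.

On that weak basis a modest improvement is expected, a 2.6-fold lower number from compound 3 to compound 4 (0.42 log units; beyond the scatter). The estimate for compound 4 in this assay is 30000 nM, with a plausible range from 8000 nM to 120000 nM.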

Compound 4, inhibition constant: 8320 nM
For compound 4 the middle estimate is 3.6-fold (0.56 log units) above the measured one; the range from low to high includes it.
By their numbers in this assay, from the lowest: compounds 4, 2 and 1 (each within the scatter of the next, the first and the last beyond it); then compound 3.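

In this assay, among the compounds shown here, putting 4-methoxyphenyl in place of cyclopropyl on a carbonyl carbon whose other neighbour is an aromatic carbon gives a 9.5-fold lower number from compound 3 to compound 4 (0.98 log units; beyond the scatter), the first measured change at this position. It is also the first single change shown to go beyond the scatter, whereas the only earlier step, a 1.7-fold lower number from compound 1 to compound 2 (0.24 log units; within the scatter), made at a different carbonyl, stayed within it, so the group at this position clearly affects the number in this assay. The change replaces a three-membered non-aromatic ring with a six-membered aromatic ring and adds heavy atoms and a hydrogen-bond acceptor, but no available measurement shows which of these differences accounts for the result.

As far as these compounds go, what remains open is whether the aromatic ring alone is enough or whether the methoxy group on it also contributes, a question that a plain phenyl group on the same carbonyl carbon would help to settle. From the compounds shown here alone, it is also open whether the same change would give a similar step with another group in place of the ethoxycarbonyl group, such as the cyclobutylcarbonyl group of compound 2.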